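Thiourea series: halogen pattern on the thiocarbonyl-side aryl ring

A few compounds are considered here, and "the series" means these few. Any claim that something is new, unique, unknown or untested is made for them only; others in the source may bear on it.

Of the compounds shown here, three carry numbers so far. Compound 1 `CNC(=O)c1cc(Oc2cccc(NC(=S)Nc3ccc(Cl)cc3Cl)c2)ccn1` gives 41200 nM in a functional assay on HCT-116 cells (Homo sapiens) for cytotoxicity, read by MTT assay, with a stated time of 48 h; a higher number here means a weaker inhibitor, a lower number a stronger inhibitor. Compound 2 `CNC(=O)c1cc(Oc2cccc(NC(=S)Nc3ccc(Cl)cc3)c2)ccn1` gives 39400 nM in this assay. Compound 3 `O=C(NCc1ccccc1)c1cc(Oc2cccc(NC(=S)Nc3ccc(Cl)cc3)c2)ccn1` gives 16500 nM in this assay. Compound 2 stands second highest of the three; its nearest neighbour is compound 1, separated by a 1.0-fold lower number from compound 1 to compound 2 (0.02 log units; within the scatter), which is within the scatter, and its furthest is compound 3, separated by a 2.4-fold lower number from compound 2 to compound 3 (0.38 log units; beyond the scatter).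

Compound 4 `CNC(=O)c1cc(Oc2cccc(NC(=S)Nc3ccc(F)c(F)c3)c2)ccn1` has not yet been measured. It differs from compound 2 in one place: 3,4-difluorophenyl in place of 4-chlorophenyl on an amide-type nitrogen. Of the measured steps, only a 1.0-fold lower number from compound 1 to compound 2 (0.02 log units; within the scatter) touches this same ring, and that step stayed within the scatter when a chloro group was taken off. The other step, a 2.4-fold lower number from compound 2 to compound 3 (0.38 log units; beyond the scatter), sits at the opposite end of the shared core and does not bear on this change. With the one halogen variation already seen on this ring making no difference beyond the scatter, the expectation for compound 4 is likewise a number close to that of compound 2. Compound 4 is expected to give 38000 nM, with a range from 15000 nM to 95000 nM. The implied step, a 1.0-fold lower number from compound 2 to compound 4 (0.02 log units; within the scatter), is expected to lie within the scatter.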

Compound 4, half-maximal inhibitory concentration: 30300 nM
Beside the measured number, compound 4's estimate is 1.3-fold (0.10 log units) above it; low and high end bracket the measured number.
By their numbers in this assay, from the lowest: compounds 3, 4, 2 and 1 (each within the scatter of the next, the first and the last beyond it).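

In this assay, for the compounds shown here, 3,4-difluorophenyl in place of 4-chlorophenyl on an amide-type nitrogen whose other neighbour is the thiocarbonyl carbon gives a 1.3-fold lower number from compound 2 to compound 4 (0.11 log units; within the scatter), the first reading at this position with fluorine rather than chlorine as the halogen. Set against the 2,4-dichlorophenyl group, the same group gives a 1.4-fold lower number from compound 1 to compound 4 (0.13 log units; within the scatter), so the three halogen patterns now seen on this ring all lie within the scatter of one another, whereas the earlier compounds covered only two chloro patterns. No measurement at hand offers an explanation for how closely these numbers sit together.

All the aryl groups on this nitrogen so far carry chlorine or fluorine only, so it remains open whether a ring bearing a methoxy group, an amine or a carboxylic acid, or a longer alkyl chain in place of the ring, would stay within the scatter of these compounds. Also open, from the compounds shown here alone, is whether the 3,4-difluorophenyl group would read the same way on the core of compound 3, whose amide end differs from that of compounds 1, 2 and 4.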